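Bromo on the aryl ring of an alpha-methylene lactam

This account rests on a few compounds, and the source may have more. Where it says the series, first, only, none or still open, it means among the compounds named here.

Measured compounds:
- compound 1 `C=C1CC(c2ccc(Br)cc2)OC1=O` — 20300 nM
- compound 2 `C=C1CC(c2ccccc2)N(C)C1=O` — 989000 nM

Both were tested in a functional assay on HL-60 cells (Homo sapiens) for cytotoxicity, read by MTT assay, with a stated time of 48 h; a higher number here means a weaker inhibitor, a lower number a stronger inhibitor. Compound 2 gives 989000 nM, the highest of the two numbers and therefore the weaker of the pair. Its nearest neighbour is compound 1, which gives 20300 nM, a much lower number that lies well beyond the scatter. Compound 1 and compound 2 differ in two places at once, so their gap cannot be assigned to a single change.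

Compound 3 `C=C1CC(c2ccc(Br)cc2)N(C)C1=O` has not yet been measured. It differs from compound 2 in one place: bromo in place of hydrogen on an aromatic carbon. Among the measured compounds shown here, no measured pair isolates this change, so its effect is an open question. Given how high the number for compound 2 is, a modest move towards a lower number is expected, but nothing more than a moderate step. The estimated step of a 3.3-fold lower number from compound 2 to compound 3 (0.52 log units; beyond the scatter) reflects that expectation. Compound 3 is therefore expected to give about 300000 nM, within a range from 80000 nM to 1500000 nM.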

Compound 3, half-maximal inhibitory concentration: 220000 nM
For compound 3 the middle estimate is 1.4-fold (0.13 log units) above the measured one, within the range that was stated.
By their numbers in this assay, from the lowest: compound 1; then compound 3; then compound 2.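

Bromo in place of hydrogen on an aromatic carbon, para to a group of 8 heavy atoms, gives a 4.5-fold lower number from compound 2 to compound 3 (0.65 log units; beyond the scatter) in this assay and is the first effect here that can be assigned to one change, showing that this position of the six-membered aromatic ring responds to it. The step is modest: compound 3 gives 220000 nM and stays at a higher number than compound 1 at 20300 nM even though both carry the bromo, so adding bromo to compound 2 does not bring its number down to that of compound 1. Nothing measured here explains why the number falls with this change.

The compounds shown leave open whether this step belongs to bromo in particular or would also appear with another group on the same aromatic carbon, such as chloro, methoxy or an amine. They also do not show whether bromo would give a similar step on another carbon of that ring.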